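The compounds below may be only part of what the source reports. "The series", "measured", "known", "first", "only" and "open" are said of these compounds alone.

Measured in a functional assay on HT cells (Homo sapiens) for antiproliferative activity, read by fluorescence, with a stated time of 72 h; a higher number here means a weaker inhibitor of growth, a lower number a stronger inhibitor of growth:
Compound 1 `CC(C)c1n[nH]c2c(NCc3ccc(-c4ccccn4)cc3)nc(SCC(O)CO)nc12`: 21 nM
Compound 2 `CC(C)c1n[nH]c2c(NCc3ccc(-c4ccccn4)cc3)nc(SCC(N)CN)nc12`: 480 nM
Compound 3 `CC(O)CSc1nc(NCc2ccc(-c3ccccn3)cc2)c2[nH]nc(C(C)C)c2n1`: 62 nM

Compound 3 holds the middle place among these three numbers in this assay. The smaller gap is a 3.0-fold higher number from compound 1 to compound 3 (0.47 log units; beyond the scatter), and the wider one is a 7.7-fold lower number from compound 2 to compound 3 (0.89 log units; beyond the scatter).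

Compound 4 `CC(C)c1n[nH]c2c(NCc3ccc(-c4ccccn4)cc3)nc(SCCN)nc12` has not yet been measured. Its difference from compound 3 is aminomethyl in place of 1-hydroxyethyl on a saturated chain carbon bound to a sulfur; in words, aminomethyl in place of 1-hydroxyethyl on a saturated chain carbon bound to a sulfur.

Among the compounds with values here, the closest precedent is a 23-fold higher number from compound 1 to compound 2 (1.36 log units; beyond the scatter), where 1,2-diaminoethyl replaced 1,2-dihydroxyethyl at the same place. The change to compound 4 is smaller, so only part of that large step is expected to carry over. Within the data shown here, the gap between compound 2 and compound 3 points the same way, but compound 2 is the only measured compound with an amino chain, so the evidence is thin. A modest rise in this assay is therefore expected, and the estimated step is a 3.1-fold higher number from compound 3 to compound 4 (0.49 log units; beyond the scatter). For compound 4 the estimated value is 190 nM, with an expected range of 60 nM to 600 nM.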

Compound 4, concentration for 50% growth inhibition: 22 nM
The estimate for compound 4 lay 8.6-fold (0.94 log units) above the measured number, outside the stated range (below it).
By their numbers in this assay, from the lowest: compounds 1 and 4 (each within the scatter of the next); then compound 3; then compound 2.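

In this assay, compound 2 had been the only amine on this sulfur-bound chain, and compound 4 shows that an amine here does not by itself go with a higher number: changing 2-hydroxypropyl to 2-aminoethyl gives a 2.8-fold lower number from compound 3 to compound 4 (0.45 log units; beyond the scatter), and removing the aminomethyl group of compound 2 gives a 22-fold lower number from compound 2 to compound 4 (1.34 log units; beyond the scatter). The 1,2-dihydroxyethyl chain and the aminomethyl chain cannot be told apart at this position, with a 1.0-fold higher number from compound 1 to compound 4 (0.02 log units; within the scatter) as the step between them. No measurement shown here accounts for these steps.

The compounds shown leave open whether a longer chain ending in an amine, a dimethylamine or a carboxylic acid at this place would stay close to compound 4 in this assay. They also leave open whether the high number of compound 2 goes with its second amine or with its branched chain.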